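Hydroxyphenyl for chlorophenyl on the sulfur of compound 2

This account rests on a few compounds, and the source may have more. Where it says the series, first, only, none or still open, it means among the compounds named here.

Two members of the series have numbers in a functional assay on HCT-116 cells (Homo sapiens) for antiproliferative activity, read by MTT assay, with a stated time of 72 h; on this read-out lower numbers stand for stronger inhibition and higher numbers for weaker inhibition. Compound 1 `O=C(CSc1cccc(O)c1)Nc1ccc2nc(NC(=O)c3cccs3)sc2c1` carries a thiophene amide on the shared core and a 3-hydroxyphenyl on the sulfur; in this assay compound 1 gives 7020 nM. Compound 2 `Cc1ccc(C(=O)Nc2nc3ccc(NC(=O)CSc4ccc(Cl)cc4)cc3s2)cc1` carries a methylbenzamide and a 4-chlorophenyl on the sulfur; in this assay compound 2 gives 2120 nM, the lower of the two numbers, with compound 1 beyond the scatter above it. The two compounds differ in two places, so their gap cannot be assigned to either change.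

Compound 3 `Cc1ccc(C(=O)Nc2nc3ccc(NC(=O)CSc4cccc(O)c4)cc3s2)cc1` keeps the methylbenzamide of compound 2 and changes only the sulfur substituent: 3-hydroxyphenyl in place of 4-chlorophenyl on a sulfur. For the measured compounds named here, no measured pair isolates this change; the only compound with the 3-hydroxyphenyl, compound 1 with 7020 nM, sits on the weaker side, which is taken as a weak hint. The step is expected to be upward and modest, a 2.1-fold higher number from compound 2 to compound 3 (0.33 log units; beyond the scatter), possibly within the scatter. Compound 3 is expected to give 4500 nM, in a range from 1500 nM to 14000 nM.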

Compound 3, half-maximal inhibitory concentration: 7730 nM
Estimate against measurement, compound 3: 1.7-fold (0.23 log units) below; low and high end bracket the measured number.
By their numbers in this assay, from the lowest: compound 2; then compounds 1 and 3 (each within the scatter of the next).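

In this assay, for the compounds shown here, 3-hydroxyphenyl in place of 4-chlorophenyl on a sulfur gives a 3.6-fold higher number from compound 2 to compound 3 (0.56 log units; beyond the scatter) with the methylbenzamide held constant, the first reading of this position with only the sulfur substituent changed. With 3-hydroxyphenyl on the sulfur, 4-methylphenyl in place of thiophen-2-yl on a carbonyl carbon gives a 1.1-fold higher number from compound 1 to compound 3 (0.04 log units; within the scatter) and so does not separate the two groups. Going by these compounds alone, of the two single changes now readable, only the one on the sulfur moves the number beyond the scatter, and no available data account for that step.

The change swaps the substituent and its ring placement together, so 3-chlorophenyl or 4-hydroxyphenyl on the sulfur would be needed to separate the two. Also open, on these data alone, are whether thiophen-2-yl and 4-methylphenyl remain equivalent with 4-chlorophenyl on the sulfur, and how an amine or a carboxylic acid on the phenyl ring would read.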